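Aryl swap on the triazole nitrogen in a chalcone series

A few compounds are considered here, and "the series" means these few. Any claim that something is new, unique, unknown or untested is made for them only; others in the source may bear on it.

Three chalcones sharing one core have been measured in a functional assay on HepG2 cells (Homo sapiens) for antiproliferative activity, read by MTT assay; on this read-out lower numbers stand for stronger inhibition and higher numbers for weaker inhibition. Compound 1 `CC1(C)CCc2c(ccc(C(=O)/C=C/c3ccc(OCc4cn(-c5ccc(Cl)cc5)nn4)cc3)c2O)O1` gives 102000 nM, compound 2 `COc1ccc(-n2cc(COc3ccc(/C=C/C(=O)c4ccc5c(c4O)CCC(C)(C)O5)cc3)nn2)c([N+](=O)[O-])c1` gives 120000 nM, and compound 3 `CC(=O)c1ccc(-n2cc(COc3ccc(/C=C/C(=O)c4ccc5c(c4O)CCC(C)(C)O5)cc3)nn2)cc1` gives 91400 nM. All three numbers are weak and sit within the scatter of one another: the step of a 1.2-fold higher number from compound 1 to compound 2 (0.07 log units; within the scatter), the step of a 1.1-fold lower number from compound 1 to compound 3 (0.05 log units; within the scatter) and the step of a 1.3-fold lower number from compound 2 to compound 3 (0.12 log units; within the scatter) are each too small to count as a change. Compound 3 therefore stands in the same band as compound 1 and compound 2, with nothing to set it apart.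

Compound 4 `CCc1ccccc1-n1cc(COc2ccc(/C=C/C(=O)c3ccc4c(c3O)CCC(C)(C)O4)cc2)nn1` has not yet been measured in this assay. It differs from compound 3 in one place: 2-ethylphenyl in place of 4-acetylphenyl on an aromatic nitrogen. For the measured compounds named here, every measured step so far alters the group on the same aromatic nitrogen, and none of them moved the number beyond the scatter. Because the steps of a 1.2-fold higher number from compound 1 to compound 2 (0.07 log units; within the scatter), a 1.1-fold lower number from compound 1 to compound 3 (0.05 log units; within the scatter) and a 1.3-fold lower number from compound 2 to compound 3 (0.12 log units; within the scatter) are all within the scatter, the expectation for compound 4 is a step of about a 1.0-fold higher number from compound 3 to compound 4 (0.02 log units; within the scatter), that is, no change beyond the scatter in either direction. Compound 4 is accordingly estimated at 95000 nM, with a range from 45000 nM to 200000 nM.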

Compound 4, half-maximal inhibitory concentration: 67800 nM
Beside the measured number, compound 4's estimate is 1.4-fold (0.15 log units) above it; measured number inside the range.
By their numbers in this assay, from the lowest: compounds 4, 3, 1 and 2 (each within the scatter of the next).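

In this assay, 2-ethylphenyl on the aromatic nitrogen stays in the same band as the three earlier groups: replacing 4-acetylphenyl gives a 1.3-fold lower number from compound 3 to compound 4 (0.13 log units; within the scatter), replacing 4-methoxy-2-nitrophenyl gives a 1.8-fold lower number from compound 2 to compound 4 (0.25 log units; within the scatter), and replacing 4-chlorophenyl gives a 1.5-fold lower number from compound 1 to compound 4 (0.18 log units; within the scatter). The earlier compounds all carried a heteroatom on the aryl group, whereas the entering 2-ethylphenyl holds carbon only, and the count of hydrogen-bond acceptors in the group falls from 1 in 4-acetylphenyl to 0 without the number leaving the scatter, so among these four compounds neither the acetyl carbonyl nor any other heteroatom on the aryl group is needed to hold the number in this band. Nothing on hand explains why these exchanges make so little difference.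

On these data alone, all four compounds carry a substituted phenyl ring on this nitrogen, so it remains open whether a benzyl group, a plain alkyl chain, or a phenyl ring bearing an amine or a carboxylic acid would move the number beyond the scatter. As far as these compounds go, it also remains open whether a change elsewhere, such as replacing the hydroxyl on the shared core with a methoxy group, would do so.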